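This account rests on a few compounds, and the source may have more. Where it says the series, first, only, none or still open, it means among the compounds named here.

Measured so far in an ADME assay on microsomes from liver (Rattus norvegicus) for metabolic stability, with a stated time of 60 min; a higher number here means that more of the compound is left, a lower number that less of the compound is left:
- Compound 1 `O=C(O)c1cc(-c2cccc(COc3ccc4c(c3)CN(Cc3ccc(C(F)(F)F)cc3)C4=O)c2)ccc1Cl`: 100%
- Compound 2 `CC(C)CCN1Cc2cc(OCc3cccc(-c4ccc(Cl)c(C(=O)O)c4)c3)ccc2C1=O`: 21%

Of these two, compound 2 stands lower, at 21%, and the gap to compound 1 lies beyond the usual scatter. Compound 3 `CCCN1Cc2cc(OCc3cccc(-c4ccc(Cl)c(C(=O)O)c4)c3)ccc2C1=O` differs from compound 2 in one place: methyl in place of isopropyl on a saturated chain carbon, two bonds along the chain from an amide-type nitrogen in a ring. In words, this is methyl in place of isopropyl on a saturated chain carbon, two bonds along the chain from an amide-type nitrogen in a ring. The same difference also reads isopentyl to propyl.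

Among the measured compounds shown here, only one measured step bears on this: a number 79 percentage points lower from compound 1 to compound 2 (beyond the scatter). That step is large and beyond the scatter, but it is a different swap, isobutyl in place of 4-(trifluoromethyl)phenyl, so its size does not carry over directly. The new change only shortens an alkyl chain, so a much smaller step seems likely. Since compound 2 gives just 21%, there is more room to rise than to fall, though the data cannot settle the direction. The expected change is a number 11 percentage points higher from compound 2 to compound 3 (beyond the scatter), a modest rise that may stay within the scatter. For compound 3 the estimated value is 32%, with an expected range of 14% to 58%.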

Compound 3, percent of the compound remaining: 96%
Compound 3: middle estimate off by 64 percentage points, on the low side; the measured number lies above the stated range.
By their numbers in this assay, from the lowest: compound 2; then compounds 3 and 1 (each within the scatter of the next).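

In this assay, methyl in place of isopropyl on a saturated chain carbon, two bonds along the chain from an amide-type nitrogen in a ring, gives a number 75 percentage points higher from compound 2 to compound 3 (beyond the scatter) and so shows that a change confined to the outer end of a small alkyl chain can have a large effect at this position. Ethyl in place of 4-(trifluoromethyl)phenyl on the saturated chain carbon bound to that nitrogen gives a number 4 percentage points lower from compound 1 to compound 3 (within the scatter) and so shows that a high number does not require the 4-(trifluoromethyl)phenyl group, since the propyl chain of compound 3 serves within the scatter. No measurement here explains why the isopentyl and propyl chains behave so differently.

Going from isopentyl to propyl both shortens the chain and removes its branch, so these compounds cannot show which of the two matters, or whether both do. A straight butyl or pentyl chain would help separate the two, while an isobutyl chain on the same nitrogen, or a chain ending in an amine, remains an open case.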